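Chloro for trifluoromethyl on the urea tail

This account rests on a few compounds, and the source may have more. Where it says the series, first, only, none or still open, it means among the compounds named here.

Compound 1 `COc1cc(Cl)cc(-c2nn(-c3cccc(NC(=O)c4ccc(Cl)c(Cl)c4)c3)cc2-c2ccncc2)c1` gives 87.8% in a functional assay on SK-MEL-28 cells (Homo sapiens) for inhibition, read by sulforhodamine B assay, with a stated time of 48 h, tested at 10 uM; on this read-out higher numbers stand for a weaker effect at the one concentration tested and lower numbers for a stronger effect.
Compound 2 `O=C(Nc1cccc(-n2cc(-c3ccncc3)c(-c3cc(O)cc(Cl)c3)n2)c1)Nc1ccc(Cl)c(Cl)c1` gives -50.9%.
Compound 3 `COc1cc(Cl)cc(-c2nn(-c3cccc(NC(=O)Nc4ccc(Cl)c(C(F)(F)F)c4)c3)cc2-c2ccncc2)c1` gives 23.6%.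

On these three numbers compound 3 stands second highest. For the measured compounds named here, compound 1 sits above it, the step being a number 64.2 percentage points lower from compound 1 to compound 3 (beyond the scatter); compound 2 sits below it by a wide margin, though no single-point step joins them. Compound 4 `COc1cc(Cl)cc(-c2nn(-c3cccc(NC(=O)Nc4ccc(Cl)c(Cl)c4)c3)cc2-c2ccncc2)c1` differs from compound 3 by chloro in place of trifluoromethyl on an aromatic carbon. Going by the values given here, the one measured step, a number 64.2 percentage points lower from compound 1 to compound 3 (beyond the scatter), alters both the amide and the tail at once, so it does not isolate this exchange. Compound 2 carries the same (3,4-dichlorophenyl)amino tail as compound 4 but differs from it at another place too; its low value is the only hint. A step downward beyond the scatter is therefore expected, a number 28.6 percentage points lower from compound 3 to compound 4 (beyond the scatter), with much uncertainty. Compound 4 is estimated at -5%, within -45% to 35%.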

Compound 4, a percentage reported as activity, at one concentration (the size of the read-out at that concentration, not a potency): 23.2%
Compound 4: middle estimate off by 28.2 percentage points, on the low side; the range from low to high includes it.
By their numbers in this assay, from the lowest: compound 2; then compounds 4 and 3 (each within the scatter of the next); then compound 1.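

In this assay there is a number 0.4 percentage points lower from compound 3 to compound 4 (within the scatter) with chloro in place of trifluoromethyl on this aromatic carbon, ortho to a chloro group, so the exchange does not separate these two urea tails. The larger changes lie elsewhere: there is a number 64.6 percentage points lower from compound 1 to compound 4 (beyond the scatter) with (3,4-dichlorophenyl)amino in place of 3,4-dichlorophenyl on the carbonyl carbon, and a number 74.1 percentage points higher from compound 2 to compound 4 (beyond the scatter) with methyl in place of hydrogen on the oxygen on the aromatic ring.

No supporting measurement accounts for these steps. As far as these compounds go, whether an amine or a carboxylic acid on this aromatic carbon would give a comparable read-out remains open.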